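Working notes on solubility across compounds 1 to 4

A few compounds are considered here, and "the series" means these few. Any claim that something is new, unique, unknown or untested is made for them only; others in the source may bear on it.

Measured so far:
- compound 1 `O=C(O)c1ccc(C(=O)/C(=C\c2ccc(F)c([N+](=O)[O-])c2)Sc2ccc(Br)cc2)cc1` — compound 1 gives < 1000 ug/mL in this assay, a limit.
- compound 2 `O=C(O)c1ccc(C(=O)/C(=C\c2ccc([N+](=O)[O-])c(F)c2)SCc2ccc(Br)cc2)cc1` — compound 2 gives < 1000 ug/mL, a limit.
- compound 3 `O=C(O)c1ccc(C(=O)/C(=C\c2ccc(Cl)c([N+](=O)[O-])c2)SCc2ccc(Br)cc2)cc1` — compound 3 gives < 1000 ug/mL, a limit.

In a physicochemical assay for solubility (on this read-out higher numbers stand for higher solubility and lower numbers for lower solubility), compound 1 stands at a limit of the assay, not at a number. The same holds for every value shown here, since (the limit of < 1000 ug/mL in this assay, at which 3 of the 3 values shown sit). Among the compounds with values here, the only step between measured compounds that differ in one place, a step that the two limits leave unreadable from compound 2 to compound 3, is therefore of unreadable size.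

The unmeasured compound 4 `O=C(O)c1ccc(C(=O)/C(=C\c2ccc(F)c([N+](=O)[O-])c2)SCc2ccc(Cl)cc2Cl)cc1` is reached from compound 1 by 2,4-dichlorobenzyl in place of 4-bromophenyl on a sulfur. Within the data shown here, no measured step touches the group on the sulfur, and the one measured step elsewhere on the core is unreadable, so there is nothing that tells the direction or size of the change in this assay.

Given that compound 1 sits at the limit, compound 4 is expected to return a limit as well, and the step that the limit leaves unreadable from compound 1 to compound 4 is expected to stay unreadable. Compound 4 is estimated at 200 ug/mL, with a range of 20 ug/mL to 1000 ug/mL.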

Compound 4, solubility: < 1000 ug/mL
Compound 4: only a limit was reported; the forecaster's own chance of this, stated with the estimate: 85%; the middle value does not contradict the limit.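

Compound 1 and compound 4 stand at the same limit in this assay, so no step between them can be read: the limit of < 1000 ug/mL in this assay, at which 4 of the 4 values shown sit.

The compounds shown leave open where each truly lies relative to that limit, and whether 2,4-dichlorobenzyl in place of 4-bromophenyl on a sulfur shifts the read-out at all.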